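The source may report more compounds than this note shows. Statements on the series, on what has been measured and on what is new or still open speak of the compounds shown alone.

Measured in an ADME assay on HepG2 2.2.15 cells (Homo sapiens) for cytotoxicity; on this read-out higher numbers stand for lower toxicity in this test and lower numbers for higher toxicity in this test:
- compound 1 `CCC(=O)OCCc1c(-c2ccccc2Cl)c2cc(Cl)ccc2[nH]c1=O`: 95000 nM
- compound 2 `O=C(OCCc1c(-c2ccccc2Cl)c2cc(Cl)ccc2[nH]c1=O)C1CCCCC1`: 38000 nM
- compound 3 `O=C(OCCc1c(-c2ccccc2Cl)c2cc(Cl)ccc2[nH]c1=O)c1cccs1`: > 1700000 nM (a limit of the assay)

Compound 3 stands at the limit of > 1700000 nM in this assay, at which 1 of the 3 values shown sits, so its place is known only as a limit. It still lies on the high side of the other two, since the data show an at least 17-fold higher number from compound 1 to compound 3 (1.25 log units; beyond the scatter) and an at least 44-fold higher number from compound 2 to compound 3 (1.65 log units; beyond the scatter). Compound 4 `O=C(/C=C/c1ccccc1)OCCc1c(-c2ccccc2Cl)c2cc(Cl)ccc2[nH]c1=O` keeps the shared core and carries 2-phenylethenyl in place of thiophen-2-yl on a carbonyl carbon.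

All three measured steps changed that same group. Exchanging ethyl for cyclohexyl gave only a 2.5-fold lower number from compound 1 to compound 2 (0.40 log units; beyond the scatter), whereas both large steps came with thiophen-2-yl entering. With thiophen-2-yl leaving, a large fall in this assay is therefore expected, towards compound 1 at 95000 nM. Compound 4 is expected at 100000 nM, with an estimated range of 25000 nM to 700000 nM. This estimate means an expected at least 17-fold lower number from compound 3 to compound 4 (1.23 log units; beyond the scatter).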

Compound 4, half-maximal cytotoxic concentration: 230000 nM
Estimate against measurement, compound 4: 2.3-fold (0.36 log units) below; the range from low to high includes it.
By their numbers in this assay, from the lowest: compound 2; then compound 1; then compound 4. At a limit, above all of these: compound 3.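

In this assay, this position now shows that an aromatic ring in the entering group does not by itself bring a compound to the level of the thiophen-2-yl ester, since 2-phenylethenyl gives an at least 7.3-fold lower number from compound 3 to compound 4 (0.86 log units; beyond the scatter). The value of compound 3 is a limit of the assay, so this step is only a bound: the limit of > 1700000 nM in this assay, at which 1 of the 4 values shown sits. Even so, a rise over cyclohexyl and ethyl is no longer unique to thiophen-2-yl, as 2-phenylethenyl also gives a 6.1-fold higher number from compound 2 to compound 4 (0.78 log units; beyond the scatter) and a 2.4-fold higher number from compound 1 to compound 4 (0.38 log units; beyond the scatter).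

The compounds shown leave open whether the sulfur and five-membered ring of thiophen-2-yl or the double bond of 2-phenylethenyl accounts for the gap. From the compounds shown here alone, a phenyl or furan-2-yl group on this carbonyl carbon would bear on that question, and the true distance of compound 3 from the others stays unknown.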